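The source may hold more compounds than are shown below. What is called first, only, known or untested is meant among the compounds shown, and "the series" means these compounds.

Compound 3 `COc1ccccc1NC(=O)CC1CCc2cc(OC)c(OC)cc21` gives 21.7% in a functional assay on the whole organism (strain Wistar) for inhibition, with Rattus norvegicus as the target, read by paw edema, with a stated time of 3 h, at a dose of 100 mg/kg (a lower number here means less inhibition, a higher number more inhibition at the dose given (going by the name of the read-out)), the lowest of the three numbers seen. Compound 1 `COc1cc2c(cc1OC)C(CC(=O)O)CC2` gives 27.5% in this assay, within the scatter of compound 3, while compound 2 `COc1cc2c(cc1OC)C(CC(=O)Nc1ccc(Br)cc1)CC2` gives 43.5%, and the step of a number 21.8 percentage points lower from compound 2 to compound 3 (beyond the scatter) lies beyond the scatter. The step of a number 16 percentage points higher from compound 1 to compound 2 (beyond the scatter) is the only other one recorded. Compound 4 `COc1cc2c(cc1OC)C(CC(=O)Nc1ccccn1)CC2` differs from compound 3 in that (pyridin-2-yl in place of 2-methoxyphenyl on an amide-type nitrogen). Within the data shown here, only the step from compound 2 to compound 3 bears on this change of the group on the amide nitrogen, and it was modest; no measured step covers pyridin-2-yl. Compound 4 is therefore expected to move a number 8.3 percentage points higher from compound 3 to compound 4 (within the scatter), within the scatter, to an estimated 30% (range 15% to 45%).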

Compound 4, a percentage reported as inhibition, in the whole organism at one dose (the size of the read-out at that dose, not a potency): 30.4%
Compound 4: the middle estimate sits 0.4 percentage points below what was measured; the measured number falls inside the stated range.
By their numbers in this assay, from the lowest: compounds 3, 1 and 4 (each within the scatter of the next); then compound 2.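

In this assay, pyridin-2-yl on the amide-type nitrogen gives a number 8.7 percentage points higher from compound 3 to compound 4 (within the scatter) and so cannot be told apart from 2-methoxyphenyl there. Against the hydroxy on the carbonyl carbon it gives a number 2.9 percentage points higher from compound 1 to compound 4 (within the scatter) and again stays within the scatter, whereas a number 13.1 percentage points lower from compound 2 to compound 4 (beyond the scatter) leaves 4-bromophenyl the only group here that stands apart from the others. Nothing on hand explains why these groups compare as they do. Still open, going by these compounds, is how an unsubstituted phenyl, a 4-chlorophenyl or a benzyl group would read on this nitrogen.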